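The compounds below may be only part of what the source reports. "The series", "measured", "known", "first", "only" and "open" are said of these compounds alone.

Measured compounds:
Compound 1, `COc1cccc(/C=C/C(=O)c2sc(Nc3ccccc3C)nc2C)c1`, in a functional assay on PC-3 cells (Homo sapiens) for cytotoxicity, read by MTT assay (on this read-out lower numbers stand for stronger inhibition and higher numbers for weaker inhibition), gives > 25000 nM, which is a limit of the assay.
Compound 2, `COc1cccc(/C=C/C(=O)c2sc(Nc3cccc(Cl)c3)nc2C)c1`, in this assay gives > 25000 nM, also a limit.

Compound 2 thus stands at the limit shared by both values shown (the limit of > 25000 nM in this assay, at which 2 of the 2 values shown sit). The step that the two limits leave unreadable from compound 1 to compound 2 cannot be read. Compound 3, `COc1cccc(/C=C/C(=O)c2sc(Nc3ccc(C)cc3)nc2C)c1`, differs from compound 2 by 4-methylphenyl in place of 3-chlorophenyl on a nitrogen on an aromatic ring. Among the compounds with values here, no measured step gives a readable size, so in this assay no step beyond the scatter is expected; the estimated step is a step that the limit leaves unreadable from compound 2 to compound 3. Compound 3 is expected at 40000 nM, with a range from 15000 nM to 150000 nM, most likely reported again as a limit.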

Compound 3, half-maximal inhibitory concentration: > 25000 nM
Compound 3 gave a limit, no number; the forecaster's own chance of this, stated with the estimate: 85%; the middle value is on the limit's open side.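

Within the data shown here, no step among compound 1, compound 2 and compound 3 can be read in this assay, since all three give only a limit: the limit of > 25000 nM in this assay, at which 3 of the 3 values shown sit. The compounds shown leave open which change to the shared core, if any, would give a readable value.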